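The source may hold more compounds than are shown below. What is called first, only, known or untested is meant among the compounds shown, and "the series" means these compounds.

Measured compounds:
compound 1 `Cn1c(-c2ccc(NC(=O)CCl)cc2)nc(-c2ccccc2)c1-c1ccccc1`: 14.4%
compound 2 `Cc1ccc2oc(SCC(=O)Nc3ccc(-c4nc(-c5ccccc5)c(-c5ccccc5)n4C)cc3)nc2c1`: 15.5%

In a functional assay on HT-29 cells (Homo sapiens) for cytotoxicity, read by MTT assay, with a stated time of 24 h, tested at 1.6 ug/mL (a higher number here means a stronger effect of the compound at the concentration tested, a lower number a weaker effect), compound 1 gives 14.4%, the smaller of the two numbers shown, though its gap to compound 2 lies within the scatter. Compound 3 `Cn1c(-c2ccc(NC(=O)CSc3nc4ccccc4s3)cc2)nc(-c2ccccc2)c1-c1ccccc1` differs from compound 1 in one place: (1,3-benzothiazol-2-yl)sulfanyl in place of chloro on a saturated chain carbon bound to a carbonyl carbon. Within the data shown here, the one measured step that bears on this is the related exchange at the same place, which was a number 1.1 percentage points higher from compound 1 to compound 2 (within the scatter). On that basis compound 3 is expected to show no change beyond the scatter, a number 1.6 percentage points higher from compound 1 to compound 3 (within the scatter). Compound 3 is therefore estimated at 16%, with a range from 8% to 25%.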

Compound 3, a percentage reported as activity, at one concentration (the size of the read-out at that concentration, not a potency): 15.3%
Beside the measured number, compound 3's estimate is 0.7 percentage points above it; low and high end bracket the measured number.
By their numbers in this assay, from the lowest: compounds 1, 3 and 2 (each within the scatter of the next).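

In this assay the (1,3-benzothiazol-2-yl)sulfanyl group on a saturated chain carbon bound to a carbonyl carbon gives a read-out no different from that of chloro (a number 0.9 percentage points higher from compound 1 to compound 3 (within the scatter)). Exchanging the group on the sulfur makes no difference either (a number 0.2 percentage points lower from compound 2 to compound 3 (within the scatter)), so chloro and both sulfur-linked groups cannot be told apart at this position at the concentration tested. No evidence is available to explain this flat result. On these data alone, whether an amine or a carboxylic acid at this place would shift the read-out remains open. So does the effect of a longer chain carrying these sulfanyl groups.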